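Adding a nitro and a hydroxyl to a weak inhibitor

The compounds below may be only part of what the source reports. "The series", "measured", "known", "first", "only" and "open" are said of these compounds alone.

Measured compounds:
compound 1 `COc1ccc([C@@H]2[C@H](Oc3ccccc3)C(=O)N2c2cc(OC)c(OC)c(OC)c2)cc1` — 35000 nM
compound 2 `COc1ccc([C@@H]2[C@H](Oc3ccccc3)C(=O)N2c2cc(OC)c(OC)c(OC)c2)cc1[N+](=O)[O-]` — 69000 nM
compound 3 `COc1cc(N2C(=O)[C@@H](Oc3ccccc3)[C@H]2c2ccc(S(C)(=O)=O)cc2)cc(OC)c1OC` — 62000 nM

In a functional assay on MCF7 cells (Homo sapiens) for antiproliferative activity, read by MTT assay, with stated times of 24 h and 72 h (a lower number here means a stronger inhibitor, a higher number a weaker inhibitor), compound 1 has the lowest of the three numbers, but its neighbours sit close: the nearest is compound 3, with a 1.8-fold higher number from compound 1 to compound 3 (0.25 log units; within the scatter), and the furthest is compound 2, with a 2.0-fold higher number from compound 1 to compound 2 (0.29 log units; within the scatter). Both steps lie within the scatter, so the three compounds cannot be told apart on these numbers; all of them are weak inhibitors.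

Compound 4 `COc1ccc([C@@H]2[C@H](Oc3ccccc3)C(=O)N2c2cc(OC)c(OC)c(OC)c2)c([N+](=O)[O-])c1O` is the unmeasured compound. Compared with compound 1 it carries a group of 12 heavy atoms (7 carbon, 1 nitrogen, 4 oxygen; one six-membered aromatic ring of carbon only) in place of a group of 8 heavy atoms (7 carbon, 1 oxygen; one six-membered aromatic ring of carbon only), on a saturated ring carbon. Among the compounds with values here, the one measured step that bears on this is the move from compound 1 to compound 2, where a nitro in place of hydrogen on an aromatic carbon gave a 2.0-fold higher number from compound 1 to compound 2 (0.29 log units; within the scatter), within the scatter. Within the data shown here, no measured pair covers the hydroxyl that also enters. The expectation is therefore a step of about a 1.4-fold higher number from compound 1 to compound 4 (0.15 log units; within the scatter), that is, nothing beyond the scatter. Compound 4 is estimated at 50000 nM, within a range from 20000 nM to 130000 nM.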

Compound 4, half-maximal inhibitory concentration: 89000 nM
Compound 4: middle estimate off by 1.8-fold (0.25 log units), on the low side; measured number inside the range.
By their numbers in this assay, from the lowest: compounds 1, 3, 2 and 4 (each within the scatter of the next, the first and the last beyond it).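

At this saturated ring carbon of the four-membered ring, replacing the 4-methoxyphenyl with the larger group carrying both nitro and hydroxyl gives a 2.5-fold higher number from compound 1 to compound 4 (0.41 log units; beyond the scatter) in this assay, so this position now shows a modest step beyond the scatter, towards weaker inhibition. The other two changes at this carbon cannot be told apart from the scatter, with a 1.3-fold higher number from compound 2 to compound 4 (0.11 log units; within the scatter) and a 1.4-fold higher number from compound 3 to compound 4 (0.16 log units; within the scatter), so the gain over compound 1 appears only across the full change and cannot be assigned to the hydroxyl or the nitro alone. Nothing measured here gives a reason for the step.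

The compounds shown leave open what a hydroxyl alone on the 4-methoxyphenyl would give. They also leave open whether an amine in place of the nitro would bring the number back towards that of compound 1.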